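The source may report more compounds than this note shows. Statements on the series, on what has been measured and on what is new or still open speak of the compounds shown alone.

Measured so far:
Compound 1 `COc1cc([C@](O)(CCN(C)C)[C@@H](c2cc3cc(Br)ccc3nc2OC)c2ccnc(OC)c2OC)cc(OC(C)C)n1` — 6.7 uL/min
Compound 2 `CCCOc1cc([C@](O)(CCN(C)C)[C@@H](c2cc3cc(Br)ccc3nc2OC)c2ccnc(OC)c2OC)cc(OC)n1` — 6.5 uL/min

Both compounds share one core and differ only in the group on an oxygen on an aromatic ring. In an ADME assay on microsomes from liver (Mus musculus) for metabolic stability (on this read-out lower numbers stand for slow clearance and higher numbers for fast clearance), compound 1 gives 6.7 uL/min and compound 2 gives 6.5 uL/min; the step of a 1.0-fold lower number from compound 1 to compound 2 (0.01 log units; within the scatter) shows no separation between them, so compound 2 sits alongside compound 1 within the scatter rather than apart from it.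

Compound 3 `COc1cc([C@](O)(CCN(C)C)[C@@H](c2cc3cc(Br)ccc3nc2OC)c2ccnc(OC)c2OC)cc(OC2CCC2)n1` carries the next variation at the same place: cyclobutyl in place of propyl on an oxygen on an aromatic ring. For the measured compounds named here, the only measured step that bears on this change is the one from compound 1 to compound 2, which was flat, and it gives no indication that exchanging one small alkyl group on this oxygen for another moves this assay. No step beyond the scatter is therefore expected, a 1.1-fold higher number from compound 2 to compound 3 (0.03 log units; within the scatter).

For compound 3 the expected value is 7 uL/min, with a range of 3.5 uL/min to 14 uL/min.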

Compound 3, intrinsic clearance in a liver preparation (reported as CLH), per the amount of preparation that the assay uses: 4.6 uL/min
For compound 3 the middle estimate is 1.5-fold (0.18 log units) above the measured one; measured number inside the range.
By their numbers in this assay, from the lowest: compounds 3, 2 and 1 (each within the scatter of the next).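

In this assay, cyclobutyl on this oxygen stays within the scatter of both open-chain groups, with a 1.4-fold lower number from compound 2 to compound 3 (0.15 log units; within the scatter) against propyl and a 1.5-fold lower number from compound 1 to compound 3 (0.16 log units; within the scatter) against isopropyl. A ring at this place therefore gives no separation from a straight or a branched chain, and compounds 1, 2 and 3 form a single group on this read-out. No measurement is available that bears on why this position gives so little separation.

As far as these compounds go, all three groups are built from carbon alone, so it remains open whether an aminoethyl group, a carboxylic acid or a longer chain such as hexyl would separate from them in this assay. Cyclopentyl or cyclohexyl would show whether a larger ring on this oxygen stays within the same group.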